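Swapping a pyridylmethyl arm for 4-methylphenyl

The compounds below may be only part of what the source reports. "The series", "measured", "known", "first", "only" and "open" are said of these compounds alone.

Compound 2 `Nc1ccccc1NC(=O)c1ccc(CSC(=S)N2CCN(Cc3ccncc3)CC2)cc1` is one of two compounds tested in a functional assay on A-375 cells (Homo sapiens) for antiproliferative activity, read by CCK-8 assay, with a stated time of 72 h, tested at 2 uM; on this read-out higher numbers stand for a stronger effect at the one concentration tested and lower numbers for a weaker effect; there compound 2 gives 33.1%, the lower of the two numbers shown, a gap that is within the scatter. Compound 1 `Nc1ccccc1NC(=O)c1ccc(CSC(=S)N2CCN(c3cccnc3)CC2)cc1` gives 40.5% in this assay. Among the measured compounds shown here, the one measured step, a number 7.4 percentage points lower from compound 1 to compound 2 (within the scatter), lies within the scatter, so the two values cannot be ordered. Compound 3 `Cc1ccc(N2CCN(C(=S)SCc3ccc(C(=O)Nc4ccccc4N)cc3)CC2)cc1` differs from compound 2 by 4-methylphenyl in place of (pyridin-4-yl)methyl on an amine nitrogen in a ring, a change at the same amine nitrogen in a ring that the step from compound 1 to compound 2 altered. That step is the only one that bears on the present change, and it was within the scatter; nothing measured shows what 4-methylphenyl does at this place. The account therefore expects no step beyond the scatter, with a number 3.9 percentage points higher from compound 2 to compound 3 (within the scatter) as the estimated shift. Compound 3 is estimated at 37% in this assay, in the range 18% to 60%.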

Compound 3, a percentage reported as inhibition, at one concentration (the size of the read-out at that concentration, not a potency): 25.8%
The estimate for compound 3 lay 11.2 percentage points above the measured number, and the stated range covers the measured number.
By their numbers in this assay, from the lowest: compounds 3, 2 and 1 (each within the scatter of the next, the first and the last beyond it).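

At this amine nitrogen in a ring, 4-methylphenyl in place of (pyridin-4-yl)methyl gives, in this assay, a number 7.3 percentage points lower from compound 2 to compound 3 (within the scatter), so compound 2 and compound 3 cannot be ordered. Set against pyridin-3-yl, however, the same group gives a number 14.7 percentage points lower from compound 1 to compound 3 (beyond the scatter), the first step at this place to pass the scatter, which shows that the group on this nitrogen can alter the read-out, though only modestly so far. No measurement is available to explain this difference.

The compounds shown leave open how phenylmethyl or pyridin-4-yl would read at this nitrogen, so the effect of the ring nitrogen cannot be separated from that of the link to the ring. They also leave open whether a simple phenyl would read closer to compound 1 or to compound 3.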